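A Sulfonyl Swap on a Growth-Inhibiting Compound

The compounds below may be only part of what the source reports. "The series", "measured", "known", "first", "only" and "open" are said of these compounds alone.

In a functional assay on RS4-11 cells (Homo sapiens) for inhibition, read by CCK-8 assay, with a stated time of 48 h, tested at 20 uM (on this read-out higher numbers stand for more inhibition of growth at the one concentration tested and lower numbers for less inhibition of growth), compound 1 (`N#C/C(=C\c1ccccc1OS(=O)(=O)c1ccccc1[N+](=O)[O-])C(=O)Nc1nnc(Cc2ccc(Cl)cc2)s1`) gives 65% and compound 2 (`Cc1ccc(Cc2nnc(NC(=O)/C(C#N)=C/c3ccccc3OS(=O)(=O)c3ccc(C)cc3)s2)cc1`) gives 66%, so compound 2 stands level with compound 1, within the usual scatter. Compound 3 (`Cc1ccc(Cc2nnc(NC(=O)/C(C#N)=C/c3ccccc3OS(=O)(=O)c3ccccc3[N+](=O)[O-])s2)cc1`) has 2-nitrophenyl in place of 4-methylphenyl on a sulfonyl sulfur. Compound 1 also carries 2-nitrophenyl there and gives 65%, so no change beyond the scatter is expected in this assay. The expected step is a number 1 percentage points lower from compound 2 to compound 3 (within the scatter). Compound 3 is estimated at 65%, with an expected range of 52% to 77%.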

Compound 3, percent growth inhibition at one concentration: "not active" (no number reported)
Nothing numeric was reported for compound 3; no gap can be computed for the estimate.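

Within the data shown here, compound 3 carries no number, only the label "not active", so no step from compound 2 to compound 3 can be read. As far as these compounds go, whether 2-nitrophenyl truly costs activity here stays open, and no supporting data bear on it.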